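This account rests on a few compounds, and the source may have more. Where it says the series, first, only, none or still open, it means among the compounds named here.

In a functional assay on Ehrlich cells (Mus musculus) for cytotoxicity, read by trypan blue exclusion and cell counting, with a stated time of 2 h (a lower number here means a stronger inhibitor, a higher number a weaker inhibitor), compound 1 `C/C(=N\N=C1\N=C(c2cc3ccccc3o2)CS1)c1nc(-c2ccccc2)[nH]c1C` gives 21.5 ug/mL, the lower of the two numbers recorded so far. Compound 2 `C/C(=N\NC(=O)CC#N)c1nc(-c2ccccc2)[nH]c1C` gives 125 ug/mL in this assay, and its gap from compound 1 lies beyond the scatter. Compound 3 `C/C(=N\N=C1\N=C(c2ccccc2)CS1)c1nc(-c2ccccc2)[nH]c1C` differs from compound 1 only by phenyl in place of 1-benzofuran-2-yl on a carbon with a double bond to nitrogen. For the measured compounds named here, no measured pair shows this change, so its effect cannot be read from the data. A modest move toward a weaker inhibitor is expected, amounting to a 1.9-fold higher number from compound 1 to compound 3 (0.27 log units; within the scatter). Compound 3 is therefore estimated to give 40 ug/mL in this assay, within a range from 15 ug/mL to 110 ug/mL.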

Compound 3, half-maximal inhibitory concentration: 19.5 ug/mL
The estimate for compound 3 lay 2.1-fold (0.31 log units) above the measured number; low and high end bracket the measured number.
By their numbers in this assay, from the lowest: compounds 3 and 1 (each within the scatter of the next); then compound 2.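

In this assay, phenyl in place of 1-benzofuran-2-yl on a carbon with a double bond to nitrogen gives a 1.1-fold lower number from compound 1 to compound 3 (0.04 log units; within the scatter), so the two compounds cannot be told apart. At this position, the group with two aromatic rings and an oxygen can thus be exchanged for a single carbon-only aromatic ring without a change beyond the scatter. Nothing available explains this result. The compounds shown leave open whether this position needs an aromatic ring at all. A methyl group, an amine or a carboxylic acid on this carbon might give quite different numbers.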